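A few compounds are considered here, and "the series" means these few. Any claim that something is new, unique, unknown or untested is made for them only; others in the source may bear on it.

The two measured compounds share one core. Compound 1 `CN(C)/C(=N/CCCCn1nc(-c2ccccc2)ccc1=O)NC#N` gives 30.3 mg/kg in a functional assay on the whole organism (stomach) with Rattus norvegicus as the target; a higher number here means that more compound is needed for the effect, a lower number that less compound is needed. Compound 2 `O=c1ccc(-c2ccccc2)nn1CCCC/N=C(\S)Nc1cccc(F)c1` reaches only the limit of this assay, > 100 mg/kg, so its own position is known no more closely than that (the limit of > 100 mg/kg in this assay, at which 1 of the 2 values shown sits). Compound 3 `N/C(S)=N/CCCCn1nc(-c2ccccc2)ccc1=O` differs from compound 2 in one place: hydrogen in place of 3-fluorophenyl on an amine nitrogen. For the measured compounds named here, no step between measured compounds bears on this change, and because compound 2 sits at a limit of > 100 mg/kg in this assay, at which 1 of the 2 values shown sits, the size of the step cannot be read from it. Going by the values given here, compound 1 supplies the only number in the set, 30.3 mg/kg. Compound 3 is expected to lie between that figure and the limit, with an expected move from compound 2 to compound 3 of an at least 1.6-fold lower number from compound 2 to compound 3 (0.22 log units; that floor lies within the scatter) toward less compound needed. Compound 3 is therefore estimated at 60 mg/kg, within a range from 15 mg/kg to 200 mg/kg.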

Compound 3, dose for half-maximal effect: 36.3 mg/kg
For compound 3 the middle estimate is 1.7-fold (0.22 log units) above the measured one; the range from low to high includes it.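

In this assay, hydrogen in place of 3-fluorophenyl on the amine nitrogen gives an at least 2.7-fold lower number from compound 2 to compound 3 (0.44 log units; beyond the scatter), the first step read at this position, and it lies beyond the scatter. Compound 2 stands at a limit and not at a number, so this step has a floor but no fixed size: the limit of > 100 mg/kg in this assay, at which 1 of the 3 values shown sits. Exchanging the whole end group on the chain gives a 1.2-fold higher number from compound 1 to compound 3 (0.08 log units; within the scatter), which lies within the scatter, so the end groups of these two compounds are not told apart in this assay.

The compounds shown leave open whether the step belongs to the fluorine or to the aromatic ring as a whole, which a plain phenyl or a methyl on that nitrogen would address. They also leave open how a shorter or longer chain would read.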